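The source may report more compounds than this note shows. Statements on the series, on what has been measured and on what is new or still open speak of the compounds shown alone.

For the measured compounds named here, in a functional assay on isolated protein for inhibition of Glucose-dependent insulinotropic receptor (Rattus norvegicus), read by HTRF and cAMP accumulation (a higher number here means a larger maximal response, a lower number a smaller maximal response), compound 2 `Cc1nc(S(C)(=O)=O)ccc1Oc1ncnc(OC2CCN(C(=O)OC3(C(F)(F)F)CCC3)CC2)c1F` gives 82%, the second highest of the three numbers measured so far. Compound 1 `CCC1(OC(=O)N2CCC(Oc3ncnc(Oc4ccc(S(C)(=O)=O)nc4C)c3F)CC2)CC1` gives 83%, and compound 3 `Cc1nc(S(C)(=O)=O)ccc1Oc1ncnc(OC2CCN(C(=O)SC(C)C)CC2)c1F` gives 81%; both numbers lie within the scatter of compound 2. Compound 4 `Cc1nc(S(C)(=O)=O)ccc1Oc1ncnc(OC2CCN(C(=O)c3noc(C(C)(C)F)n3)CC2)c1F` has not yet been measured. It differs from compound 2 in a single place: a group of 9 heavy atoms (5 carbon, 2 nitrogen, 1 oxygen, 1 fluorine; one five-membered aromatic ring with 3 hetero atoms) in place of a group of 9 heavy atoms (5 carbon, 1 oxygen, 3 fluorine; one four-membered non-aromatic ring of carbon only), on a carbonyl carbon. Going by the values given here, three measured steps bear on exchanges at this carbonyl carbon: a number 1 percentage points lower from compound 1 to compound 2 (within the scatter), a number 2 percentage points lower from compound 1 to compound 3 (within the scatter) and a number 1 percentage points lower from compound 2 to compound 3 (within the scatter). None of them left the scatter. The expectation is therefore that no change at the digits printed from compound 2 to compound 4 (within the scatter) describes the estimated step in this assay, no change beyond the scatter. Compound 4 is estimated at 82%, with a range from 72% to 92%.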

Compound 4, largest response reached (reported as efficacy), in percent of the reference or control that the assay uses: 74%
For compound 4 the middle estimate is 8 percentage points above the measured one; the range from low to high includes it.
By their numbers in this assay, from the lowest: compounds 4, 3, 2 and 1 (each within the scatter of the next).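

With the 3-hetero-atom five-membered aromatic ring on the carbonyl carbon, the group entering this place no longer reaches the carbonyl through oxygen or sulfur, yet this assay stays within the scatter in all three new steps (a number 8 percentage points lower from compound 2 to compound 4 (within the scatter); a number 7 percentage points lower from compound 3 to compound 4 (within the scatter); a number 9 percentage points lower from compound 1 to compound 4 (within the scatter)). For the compounds shown here, these are the largest steps at this position so far, though none is beyond the scatter. Nothing at hand gives a reason for these numbers.

The compounds shown leave open how an amine or a phenyl ring on this carbonyl carbon would read in this assay. They also leave open whether any exchange here can leave the scatter.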